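A Chloro-to-Hydrogen Change Tested Against Tumor Cell Growth

The source may report more compounds than this note shows. Statements on the series, on what has been measured and on what is new or still open speak of the compounds shown alone.

Compound 1 `Cc1ccc2nc(/N=C3\C(=O)N(CN(c4ccccc4)c4ccccc4)c4cccc(Cl)c43)sc2c1` was examined in a functional assay on MCF7 cells (Homo sapiens) for cytotoxicity, read by sulforhodamine B assay, with a stated time of 48 h (on this read-out lower numbers stand for stronger inhibition of growth and higher numbers for weaker inhibition of growth), where compound 1 gives 24300 nM. Two further compounds, compound 3 `Cc1ccc2nc(/N=C3\C(=O)N(CN(C)C)c4cccc(Cl)c43)sc2c1` and compound 2 `Cc1ccc2nc(/N=C3\C(=O)N(CN(C)C)c4ccccc43)sc2c1`, are built on a core that is not the same as that of compound 1; the difference between the two cores is not broken down here. In this assay compound 3 gives 20700 nM, and in the same assay compound 2 gives 29200 nM. The values of compound 1 and compound 3 lie within the usual scatter of each other, as do those of compound 1 and compound 2, so no order among the three can be read from these numbers.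

Compound 3 and compound 2 differ in one place only, (hydrogen in place of chloro on an aromatic carbon), and this change made a 1.4-fold higher number from compound 3 to compound 2 (0.15 log units; within the scatter).

Compound 4 `Cc1ccc2nc(/N=C3\C(=O)N(CN(c4ccccc4)c4ccccc4)c4ccccc43)sc2c1` has not yet been measured. Going by the values given here, it differs from compound 1 by hydrogen in place of chloro on an aromatic carbon, which is the same change as the one between compound 3 and compound 2, made at the same kind of place. Because the measured step was a 1.4-fold higher number from compound 3 to compound 2 (0.15 log units; within the scatter), the step from compound 1 to compound 4 is expected to be a 1.3-fold higher number from compound 1 to compound 4 (0.11 log units; within the scatter) in this assay. On this basis compound 4 is estimated to give 31000 nM, with a plausible range from 15000 nM to 65000 nM.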

Compound 4, concentration for 50% growth inhibition: 39200 nM
Estimate against measurement, compound 4: 1.3-fold (0.10 log units) below; the measured number falls inside the stated range.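

In this assay, hydrogen in place of chloro on an aromatic carbon of the core of compound 1 gave a 1.6-fold higher number from compound 1 to compound 4 (0.21 log units; within the scatter). Set beside the same change on the other core, this step cannot be told apart from the earlier one: the same change on two cores in this assay, a 1.4-fold higher number (0.15 log units; within the scatter) from compound 3 to compound 2 and a 1.6-fold higher number (0.21 log units; within the scatter) from compound 1 to compound 4, 1.1-fold (0.06 log units) apart, within the scatter of two such steps. This shows that the two steps agree in this assay, but each lies within the scatter, so it does not show that removing chloro affects growth inhibition on either core, and two cores say nothing about how the change would behave on a third.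

The compounds shown leave open whether a different group on this aromatic carbon, such as fluoro, bromo, methoxy or a nitrile, would give a step that stands clear of the scatter on either core. They also leave open whether the chloro-to-hydrogen change would read the same with a cyclic amine such as morpholine or piperidine in place of the amine groups carried by these four compounds, and whether any such group would move the numbers well away from those seen so far.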